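Hydroxy in place of fluoro on an aromatic carbon

The source may report more compounds than this note shows. Statements on the series, on what has been measured and on what is new or still open speak of the compounds shown alone.

- compound 1 `Cn1c(=O)c(S(=O)(=O)c2ccc(OC(=O)CCCCC3SCC4NC(=O)NC43)cc2)cc2cnc(Nc3ccc4[nH]ccc4c3)nc21` gives 250 nM
- compound 2 `Cn1c(=O)c(S(=O)(=O)c2ccc(F)cc2)cc2cnc(Nc3ccc4[nH]ccc4c3)nc21` gives 200 nM

In a functional assay on BT-474 cells (Homo sapiens) for inhibition, read by trypan blue exclusion, with a stated time of 72 h (on this read-out lower numbers stand for stronger inhibition of growth and higher numbers for weaker inhibition of growth), compound 2 stands at 200 nM and lies within the usual scatter of compound 1 at 250 nM so the two cannot be ranked against each other.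

Compound 3 `Cn1c(=O)c(S(=O)(=O)c2ccc(O)cc2)cc2cnc(Nc3ccc4[nH]ccc4c3)nc21` has not yet been measured. It departs from compound 2 in a single place, on an aromatic carbon of a six-membered aromatic ring of carbon only, para to a large group. The change there is hydroxy in place of fluoro on an aromatic carbon and it puts hydroxy in place of fluoro.

Going by the values given here, no measured pair isolates this swap, so the data give no direct size for it. With compound 2 at 200 nM as the closest reference, no shift beyond the scatter is expected in this assay in either direction. The expected 1.1-fold lower number from compound 2 to compound 3 (0.05 log units; within the scatter) is therefore small. For compound 3 the estimated value is 180 nM with a likely range from 60 nM to 550 nM for now.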

Compound 3, concentration for 50% growth inhibition: 200 nM
For compound 3 the middle estimate is 1.1-fold (0.05 log units) below the measured one; the range from low to high includes it.
By their numbers in this assay, from the lowest: compounds 2, 3 and 1 (each within the scatter of the next).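

In this assay, going by these compounds alone, replacing the fluoro of the 4-fluorophenyl group with hydroxy gives no change at the digits printed from compound 2 to compound 3 (within the scatter), the first direct reading of a swap at this aromatic carbon. It shows that this carbon accepts a group with a hydrogen-bond donor and acceptor in place of one counted with neither, with no difference that this assay can resolve, and compound 1, which carries a far larger group on the same carbon, gives 250 nM, so all three compounds stay within the scatter of their neighbours in the ranking. Nothing available explains why the two groups read alike, and the result on its own gives no cause.

The compounds shown leave open whether an amine, a carboxylic acid or a methoxy group on this carbon would also stay level with compound 2, or whether one of them would finally separate from it beyond the scatter. They also leave open whether the swap from fluoro to hydroxy would read the same way on a different carbon of this ring, since only this one place has been compared.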